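This account rests on a few compounds, and the source may have more. Where it says the series, first, only, none or still open, it means among the compounds named here.

Measured compounds:
Compound 1, `Cc1nc(-c2cccc(C(=O)N3CCCC(C(=O)Nc4ccc(Cl)cc4)C3)c2)no1`: 0%
Compound 2, `O=C(Nc1cccc(OCCc2ccccn2)c1)C1CCCN(C(=O)c2cc(C(F)(F)F)cc(C(F)(F)F)c2)C1`: 5%

In an ADME assay on PC-3 cells (Homo sapiens) for cytotoxicity, read by WST assay, tested at 100 uM (on this read-out higher numbers stand for more inhibition at the one concentration tested (going by the name of the read-out) and lower numbers for less inhibition), compound 2 gives the higher of the two numbers, but its gap to compound 1 lies within the scatter, so the two cannot be told apart. Compound 3, `Cc1nc(-c2cccc(NC(=O)C3CCCN(C(=O)c4cc(C(F)(F)F)cc(C(F)(F)F)c4)C3)c2)cs1`, differs from compound 2 in one place: 2-methyl-1,3-thiazol-4-yl in place of 2-(pyridin-2-yl)ethoxy on an aromatic carbon. Among the measured compounds shown here, no step between measured compounds is known here, and both measured numbers sit near zero. Compound 3 is therefore expected to show no step beyond the scatter, no change at the digits printed from compound 2 to compound 3 (within the scatter). For compound 3 the estimate is 5%, expected to fall between 0% and 20%.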

Compound 3, a percentage reported as inhibition, at one concentration (the size of the read-out at that concentration, not a potency): 1%
Compound 3: the middle estimate sits 4 percentage points above what was measured; the range from low to high includes it.
By their numbers in this assay, from the lowest: compounds 1, 3 and 2 (each within the scatter of the next).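

In this assay, putting 2-methyl-1,3-thiazol-4-yl in place of 2-(pyridin-2-yl)ethoxy on this aromatic carbon, meta to a large group, gives a number 4 percentage points lower from compound 2 to compound 3 (within the scatter). At this position, then, the two groups cannot be told apart on this read-out, even though they differ in ring size and in chain. No available measurement gives a reason for this result. The compounds shown leave open whether an amine or a carboxylic acid on this carbon would give a number beyond the scatter from compound 2. They also leave open whether any group here can move this read-out at all.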